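Chloro to Bromo on a Shared Core: Two Pairs Compared

The compounds below may be only part of what the source reports. "The series", "measured", "known", "first", "only" and "open" are said of these compounds alone.

Four compounds built on related frameworks are compared in a functional assay on HEK293 cells for antagonist activity at metabotropic glutamate receptor 5 (Rattus norvegicus), read by calcium flux; a higher number here means a weaker inhibitor, a lower number a stronger inhibitor. Compound 1 `CN(c1cccc(Br)c1)c1ncnc2ccc(Cl)cc12` and compound 3 `CN(c1cccc(Br)c1)c1ncnc2ccc(Br)cc12` share one core, while compound 2 `Clc1ccc2ncnc(Oc3cccc(Br)c3)c2c1` and compound 4 `Brc1cccc(Oc2ncnc3ccc(Br)cc23)c1` share another; the difference between the two cores is not broken down here.

In this assay compound 1 reaches only a limit, giving > 30000 nM. Compound 3 likewise stops at a limit, giving > 30000 nM. For the measured compounds named here, compound 2 is the one compound with an actual number in this assay, giving 6570 nM.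

The change from compound 1 to compound 3 is bromo in place of chloro on an aromatic carbon. Its size is a step that the two limits leave unreadable from compound 1 to compound 3 because both ends of that pair sit at the limit of > 30000 nM in this assay, at which 2 of the 3 values shown sit.

The same change, (bromo in place of chloro on an aromatic carbon), links compound 2 to compound 4. Here the starting point is a number rather than a limit, so the step will become readable once compound 4 is measured. The expectation for the step from compound 2 to compound 4 is a 1.1-fold lower number from compound 2 to compound 4 (0.04 log units; within the scatter), resting on compound 2 at 6570 nM, with the pair from compound 1 to compound 3 offering no readable size to lean on. Compound 4 is therefore estimated at 6000 nM, with a likely range from 2000 nM to 20000 nM.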

Compound 4, half-maximal inhibitory concentration: > 10000 nM
Compound 4: only a limit was reported (the forecaster's own chance of this, stated with the estimate: 15%); middle value at least 1.6-fold (0.22 log units) from the limit.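

On the core of compound 2, bromo in place of chloro on an aromatic carbon gives in this assay an at least 1.5-fold higher number from compound 2 to compound 4 (0.18 log units; that floor lies within the scatter), which shows that the change brought no lower number here, but this is only a floor, and a floor within the scatter does not by itself establish a real loss of activity. Compound 4 stops at a limit, > 10000 nM, so the true size of the step stays unknown and could be much larger, and the step has an open upper end because of this limit: the limit of > 10000 nM in this assay, at which 1 of the 4 values shown sits. On the core of compound 1, the same change cannot be read, so the series offers no second size to set beside the first and cannot show whether the change carries over from one core to the other, because both ends of that pair rest on one limit: the limit of > 30000 nM in this assay, at which 2 of the 4 values shown sit.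

What the compounds shown leave open is how a group other than these two halogens, such as fluoro, methoxy, nitrile or an amine, would fare on that same aromatic carbon. They also leave open where compound 4 truly lies beyond its limit, and a firm number there would turn this floor into a measured step.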